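The compounds below may be only part of what the source reports. "The series", "measured", "known", "first", "only" and "open" are said of these compounds alone.

Working notes on the series. Three compounds have been run in an assay on membranes from Chem-1 cells for displacement of a labelled ligand from prostaglandin E2 receptor EP3 subtype (Homo sapiens), read by scintillation counting, with a stated time of 2 h; a higher number here means a weaker inhibitor, a lower number a stronger inhibitor. Compound 1 `Cc1cc(C(/C=C2\OC(=O)NC2=O)C(C)C)c(=O)[nH]c1-c1ccc2cccc(F)c2c1` gives 23 nM in this assay. Compound 2 `CC(C)C(c1ccc(-c2ccc3cccc(F)c3c2)[nH]c1=O)C1NC(=O)NC1=O` gives 50 nM. Compound 3 `CCC(/C=C1\OC(=O)NC1=O)(CC)c1ccc(-c2ccc3cccc(C(C)C)c3c2)[nH]c1=O` gives 120 nM. Among these three numbers compound 2 stands second highest: compound 1 sits at a lower number, and that gap lies beyond the scatter, while compound 3 sits at a higher number, again beyond the scatter. Among the measured compounds shown here, no pair among the measured compounds differs in a single place, so no step has been worked out from the measured data.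

The next compound, compound 4 `CC(C)C(c1ccc(-c2ccc3cccc(F)c3c2)[nH]c1=O)C1C(=O)NC(=O)N1C`, is derived from compound 2 by one change: methyl in place of hydrogen on an amide-type nitrogen in a ring. For the measured compounds named here, nothing among compounds 1, 2 and 3 shows what a change on this amide-type ring nitrogen does in this assay, so the direction rests on no measured step. The working expectation is that compound 4 moves to a somewhat higher number than compound 2, a step of a 3.0-fold higher number from compound 2 to compound 4 (0.48 log units; beyond the scatter), though a step within the scatter cannot be ruled out. Compound 4 is therefore estimated at 150 nM in this assay, with a range from 50 nM to 500 nM.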

Compound 4, inhibition constant: 46 nM
For compound 4 the middle estimate is 3.3-fold (0.51 log units) above the measured one, and the stated range ends above it.
By their numbers in this assay, from the lowest: compounds 1, 4 and 2 (each within the scatter of the next, the first and the last beyond it); then compound 3.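

In this assay, among the compounds shown here, methyl in place of hydrogen on the amide-type nitrogen in the five-membered ring, next to the ring atom that bears a large group, gives a 1.1-fold lower number from compound 2 to compound 4 (0.04 log units; within the scatter) and so provides the first reading of a change at this nitrogen. For this one pair, the amide hydrogen can give way to a methyl without a shift beyond the scatter, so a hydrogen on this nitrogen is not needed to keep the number in this range in this assay. No supporting measurement is available that would explain why this step is so small.

Whether this nitrogen also tolerates something larger or of a different kind, such as an ethyl group, a longer chain, or a chain ending in an amine or a carboxylic acid, remains open, since methyl is the only replacement shown here. Also open, going by these compounds, are what the same methyl would do on the other ring nitrogen, and whether the flat step would hold on a different core, such as that of compound 3.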